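Cyano in place of hydrogen: from compound 3 to compound 4

A few compounds are considered here, and "the series" means these few. Any claim that something is new, unique, unknown or untested is made for them only; others in the source may bear on it.

Measured in a functional assay on C6 cells (Rattus norvegicus) for cytotoxicity, read by MTT assay, with a stated time of 24 h, tested at 100 ug/mL; on this read-out lower numbers stand for a stronger effect and higher numbers for a weaker effect at the one concentration tested:
Compound 1 `O=C(CSc1nnnn1-c1ccccc1)N/N=c1/scc(-c2ccc(F)cc2)n1-c1ccccc1` gives 35.8%.
Compound 2 `Cn1cnnc1SCC(=O)N/N=c1/scc(-c2ccc(C#N)cc2)n1-c1ccccc1` gives 55.2%.
Compound 3 `O=C(CSc1nnnn1-c1ccccc1)N/N=c1/scc(-c2ccccc2)n1-c1ccccc1` gives 35.8%.

Compound 3 stands level with compound 1 on this assay; the two together are the lowest of the three numbers, while compound 2 lies higher by an amount beyond the scatter. Among the measured compounds shown here, the one step measured between single-point neighbours, no change at the digits printed from compound 1 to compound 3 (within the scatter), shows that swapping fluoro for hydrogen at that aromatic carbon left the read-out unchanged.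

Compound 4 `N#Cc1ccc(-c2cs/c(=N/NC(=O)CSc3nnnn3-c3ccccc3)n2-c2ccccc2)cc1` has not yet been measured. It differs from compound 3 by cyano in place of hydrogen on an aromatic carbon. For the measured compounds named here, no measured step isolates this exact change. Compound 2 carries a cyano group as well, but differs from compound 4 elsewhere in the molecule too, so its higher number bears on the question only loosely. The measured step from compound 1 to compound 3 was within the scatter, so a small effect of a single substituent at this position is plausible; the value of compound 2 leaves room for a rise.

On balance a modest rise in the number, that is a somewhat weaker effect, is expected for compound 4, amounting to a number 7.2 percentage points higher from compound 3 to compound 4 (within the scatter). Compound 4 is therefore estimated at 43%, with a range from 28% to 60%.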

Compound 4, a percentage reported as activity, at one concentration (the size of the read-out at that concentration, not a potency): 59.8%
The estimate for compound 4 lay 16.8 percentage points below the measured number, and the stated range covers the measured number.
By their numbers in this assay, from the lowest: compounds 1 and 3 (each within the scatter of the next); then compounds 2 and 4 (each within the scatter of the next).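

In this assay, the aromatic carbon para to a large group turns out to be sensitive to its substituent: cyano in place of hydrogen gives a number 24 percentage points higher from compound 3 to compound 4 (beyond the scatter), and cyano in place of fluoro gives a number 24 percentage points higher from compound 1 to compound 4 (beyond the scatter). The earlier exchange of fluoro and hydrogen at this carbon had left the number unchanged, so the position had seemed indifferent, and cyano is the first group shown to separate itself from both. With cyano at this carbon, 1-phenyl-1H-tetrazol-5-yl in place of 4-methyl-4H-1,2,4-triazol-3-yl on the sulfur gives a number 4.6 percentage points higher from compound 2 to compound 4 (within the scatter), so in this pair the exchange on the sulfur does not move the number beyond the scatter.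

Nothing measured here accounts for the step at this carbon. Still open, as far as these compounds go, is whether an amine, a carboxylic acid or a methoxy group at this carbon would stand with cyano or with hydrogen and fluoro, and whether the exchange on the sulfur would also stay within the scatter with hydrogen or fluoro at this carbon.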